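Shortening the chain of compound 3

The compounds below may be only part of what the source reports. "The series", "measured", "known", "first", "only" and "open" are said of these compounds alone.

In a physicochemical assay for lipophilicity, read by HPLC, measured as octanol-water partition, with a stated time of 24 h (on this read-out higher numbers stand for higher lipophilicity and lower numbers for lower lipophilicity), compound 3 (`CCCNc1nc(Nc2ccc(OC)cc2)nc2ccccc12`) gives > 5 as its result, which is a limit and not a number. Compound 1 (`COc1ccc(Nc2nc(NC3CCCC3)c3ccccc3n2)cc1`) gives > 5 as its result, also a limit. From the compounds shown here alone, compound 3 therefore stands at the limit of > 5 in this assay, at which 2 of the 3 values shown sit, and its true value stays unknown. Compound 2 (`COc1ccc(Nc2nc(NCCCO)c3ccccc3n2)cc1`) gives a real number of 2.54 in this read-out. Compound 4 (`CNc1nc(Nc2ccc(OC)cc2)nc2ccccc12`) has hydrogen in place of ethyl on a saturated chain carbon bound to a nitrogen on an aromatic ring, so propyl becomes methyl (hydrogen in place of ethyl on a saturated chain carbon bound to a nitrogen on an aromatic ring). The closest evidence is weak: there is a step that the two limits leave unreadable from compound 1 to compound 3 and also a number at least 2.46 log units higher from compound 2 to compound 3 (beyond the scatter) when hydroxy gives way to hydrogen. Neither is this same change, though the second shows that the chain can matter greatly, so a moderate fall is expected rather than a large one. The expected result is a number at least 0.60 log units lower from compound 3 to compound 4 (beyond the scatter) in this assay for this change. Compound 4 is estimated at 4.4 with an expected range from 3.7 to 5 in this assay.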

Compound 4, partition coefficient: 3.21
Beside the measured number, compound 4's estimate is 1.19 log units above it; measured number outside the range, below it.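

Among these compounds, compound 4 gives the first real number in this assay for a chain without hydroxy on this nitrogen, so cutting propyl to methyl brings the result down from the limit (a number at least 1.79 log units lower from compound 3 to compound 4 (beyond the scatter)). Replacing cyclopentyl with methyl reads the same way (a number at least 1.79 log units lower from compound 1 to compound 4 (beyond the scatter)), yet the methyl compound still lies higher than the 3-hydroxypropyl compound (a number 0.67 log units higher from compound 2 to compound 4 (beyond the scatter)). The first two steps give only a minimum size, since each starts from a limit: the limit of > 5 in this assay, at which 2 of the 4 values shown sit.

An ethyl chain on this nitrogen could show where between methyl and propyl the result reaches the limit. From the compounds shown here alone, how a terminal amine on the chain would compare with hydroxy also stays open.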